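Swapping Methylsulfanyl for Trifluoromethoxy: Expected Cell Tolerance

The source may hold more compounds than are shown below. What is called first, only, known or untested is meant among the compounds shown, and "the series" means these compounds.

Compound 2 `CSc1cccc(N2C(=O)CN(c3cccc(C(F)(F)F)c3)CC2C(=O)NC2CCCC2)c1` and compound 1 `CSc1cccc(N2C(=O)CN(c3ccc(C(F)(F)F)cc3)CC2C(=O)NC2CCCC2)c1` share one core and differ only in where a trifluoromethyl sits on a phenyl ring attached to an amine nitrogen in a ring. In an ADME assay on HepG2 cells (Homo sapiens) for cytotoxicity (a lower number here means that less compound is tolerated, a higher number that more compound is tolerated), compound 2 gives 20000 nM, and compound 1 gives 10000 nM. Going by the values given here, the step of a 2.0-fold higher number from compound 1 to compound 2 (0.30 log units; within the scatter) is the only measured step here, and it shows that moving the trifluoromethyl from one ring position to another leaves the tolerated concentration essentially unchanged; the two compounds cannot be told apart on these numbers.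

Compound 3 `O=C(NC1CCCC1)C1CN(c2cccc(C(F)(F)F)c2)CC(=O)N1c1cccc(OC(F)(F)F)c1` takes the change (trifluoromethoxy in place of methylsulfanyl on an aromatic carbon). Among the compounds with values here, no measured pair involves this exchange, so the single measured step does not bear on it directly; it only shows that the shared core tolerates a change on one of its aryl rings without a shift beyond scatter. With nothing pointing in either direction, no step beyond the scatter is expected in this assay, and the step of no change at the digits printed from compound 2 to compound 3 (within the scatter) is the estimate that follows. Compound 3 is therefore expected to give about 20000 nM, within a range from 7000 nM to 50000 nM.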

Compound 3, half-maximal cytotoxic concentration: 8000 nM
Compound 3: the middle estimate sits 2.5-fold (0.40 log units) above what was measured; measured number inside the range.
By their numbers in this assay, from the lowest: compounds 3, 1 and 2 (each within the scatter of the next, the first and the last beyond it).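

In this assay the exchange of methylsulfanyl for trifluoromethoxy on this aromatic carbon gives a 2.5-fold lower number from compound 2 to compound 3 (0.40 log units; beyond the scatter) and so registers a real, if small, loss of tolerated concentration. Going by these compounds alone, the earlier shift of the trifluoromethyl group could not show this, since its step stayed within the scatter, so this is the first sign that the cells respond to what sits at this place on the other aryl ring of the shared core. Nothing available here explains why the number falls with this exchange.

Still open, as far as these compounds go, is whether the lower number is particular to trifluoromethoxy or would also appear with other groups at the same place, such as a methoxy group, a chlorine atom or a nitrile, and whether any group there would instead raise the number. Also open, from the compounds shown here alone, is whether the same exchange would give a similar step on the core of compound 1, where the trifluoromethyl sits in the other ring position, since a single pair cannot show whether the step carries over to a related compound.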